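From carboxymethyl to carbamoyl: what to expect for compound 4

The source may hold more compounds than are shown below. What is called first, only, known or untested is meant among the compounds shown, and "the series" means these compounds.

Three compounds share one core and differ in the group on the amide-type nitrogen. In a functional assay on CLL cells (Homo sapiens) for cytotoxicity, read by MTT assay, with a stated time of 48 h (a higher number here means that more compound is needed for the effect, a lower number that less compound is needed), compound 1 `C=C(CC)C(=O)c1ccc(OCC(=O)Nc2ccc(C(=O)O)cc2)c(Cl)c1Cl` gives 5000 nM, compound 2 `C=C(CC)C(=O)c1ccc(OCC(=O)Nc2ccc(O)c(Cl)c2)c(Cl)c1Cl` gives 5500 nM, and compound 3 `C=C(CC)C(=O)c1ccc(OCC(=O)Nc2ccc(CC(=O)O)cc2)c(Cl)c1Cl` gives 3200 nM. These numbers all lie within the usual scatter of one another, so compound 3 cannot be ranked apart from the other two.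

Compound 4 `C=C(CC)C(=O)c1ccc(OCC(=O)Nc2ccc(C(N)=O)cc2)c(Cl)c1Cl` differs from compound 3 in one place: it has carbamoyl in place of carboxymethyl on an aromatic carbon, para to a large group (carbamoyl in place of carboxymethyl on an aromatic carbon). Going by the values given here, two measured steps bear on this change. The closer one swaps carboxy for carboxymethyl on an aromatic carbon and gives a 1.6-fold lower number from compound 1 to compound 3 (0.19 log units; within the scatter). The other replaces the whole 4-carboxyphenyl with 3-chloro-4-hydroxyphenyl and gives a 1.1-fold higher number from compound 1 to compound 2 (0.04 log units; within the scatter). Among the compounds with values here, both steps stay within the scatter, although no measured compound yet carries carbamoyl, so this evidence is indirect.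

No change beyond the scatter is therefore expected in this assay. The expected step is a 1.3-fold higher number from compound 3 to compound 4 (0.10 log units; within the scatter). The estimate for compound 4 is 4000 nM, with an expected range from 2000 nM to 8000 nM.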

Compound 4, half-maximal effective concentration: 3700 nM
The estimate for compound 4 lay 1.1-fold (0.03 log units) above the measured number, within the range that was stated.
By their numbers in this assay, from the lowest: compounds 3, 4, 1 and 2 (each within the scatter of the next).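

With the ring kept as in compound 1 and compound 3, carbamoyl now stands in the place that carried a carboxy-bearing group in both, and in this assay the swap for carboxymethyl gives a 1.2-fold higher number from compound 3 to compound 4 (0.06 log units; within the scatter) in this series. The smallest possible edit of compound 1, amino in place of hydroxy on a carbonyl carbon, gives a 1.4-fold lower number from compound 1 to compound 4 (0.13 log units; within the scatter) as its result, while exchanging the whole 3-chloro-4-hydroxyphenyl of compound 2 for 4-carbamoylphenyl gives a 1.5-fold lower number from compound 2 to compound 4 (0.17 log units; within the scatter) as its result. So in these four compounds, a carboxy group at this position is not required for a number in this range, and neither the loss of that group nor the shorter carbamoyl separates compound 4 from the others.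

Going by these compounds, whether an amine, a methyl ester or a longer chain ending in carbamoyl at this same place would also stay within the scatter remains open. Going by these compounds alone, also open is whether any group here can move the number beyond the scatter at all, since every step so far stays inside it.

No measurement shown offers an explanation for these results.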